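This account rests on a few compounds, and the source may have more. Where it says the series, first, only, none or still open, it means among the compounds named here.

In an ADME assay on BJ cells (Homo sapiens), read by MTT assay, with a stated time of 72 h (on this read-out higher numbers stand for weaker inhibition and lower numbers for stronger inhibition), three compounds sharing one core have been measured. Compound 1 `COc1ncnc2c1c(-c1cc3ccccc3o1)cn2[C@@H]1O[C@H](CO)[C@@H](O)[C@H]1O` gives 22400 nM and compound 2 `CSc1ncnc2c1c(-c1ccoc1)cn2[C@@H]1O[C@H](CO)[C@@H](O)[C@H]1O` gives 98800 nM on this scale. Compound 3 `CNc1ncnc2c1c(-c1ccoc1)cn2[C@@H]1O[C@H](CO)[C@@H](O)[C@H]1O` reads 96300 nM and so sits level with compound 2 and well above compound 1.

Compound 4 `C#Cc1cn([C@@H]2O[C@H](CO)[C@@H](O)[C@H]2O)c2ncnc(NC)c12` swaps furan-3-yl for ethynyl on an aromatic carbon of the core, and ethynyl in place of furan-3-yl on an aromatic carbon gives the count of what leaves and what enters. Among the compounds with values here, the only measured single change is a 1.0-fold lower number from compound 2 to compound 3 (0.01 log units; within the scatter) and lies within the scatter, but it sits on a different carbon and says nothing direct about this one. Within the data shown here, no measured step replaces furan-3-yl with ethynyl. Compound 1 carries another group on that carbon and also differs elsewhere, so its 22400 nM is only a hint that this carbon can matter. A modest move toward stronger inhibition in this assay is expected, with a 1.9-fold lower number from compound 3 to compound 4 (0.28 log units; within the scatter) as the estimated step and little certainty about it. The estimate for compound 4 is 50000 nM with an expected range from 8000 nM to 150000 nM on the same scale.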

Compound 4, half-maximal inhibitory concentration: 86000 nM
Estimate against measurement, compound 4: 1.7-fold (0.24 log units) below; the measured number falls inside the stated range.
By their numbers in this assay, from the lowest: compound 1; then compounds 4, 3 and 2 (each within the scatter of the next).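

Putting ethynyl in place of furan-3-yl on this aromatic carbon gives a 1.1-fold lower number from compound 3 to compound 4 (0.05 log units; within the scatter) in this assay, so the two compounds read as level. Within the data shown here, this is the first step at this carbon with the rest of the molecule held fixed, and it shows that a five-membered aromatic ring with one hetero atom can be exchanged for a group with no ring at all without any change that stands out from the scatter. No supporting measurement accounts for why these two groups read alike.

The compounds shown leave open how an amine, a carboxylic acid or a longer chain ending in a triple bond would read on this carbon with methylamino held fixed. They also leave open whether ethynyl would read the same way with methylsulfanyl in place of methylamino.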